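Swapping the aryl on the ring nitrogen: compound 3 to compound 4

A few compounds are considered here, and "the series" means these few. Any claim that something is new, unique, unknown or untested is made for them only; others in the source may bear on it.

Of the compounds shown here, three sharing one core have so far been measured in a functional assay on PC-12 cells (Rattus norvegicus) for cytotoxicity, read by MTT assay, with stated times of 2 h and 24 h, tested at 1 uM; a higher number here means a stronger effect of the compound at the concentration tested, a lower number a weaker effect. Compound 1 `Oc1cc(C(F)(F)F)ccc1-c1nc(-c2ccccc2O)n(-c2ccc(OC(F)(F)F)cc2)n1` gives 65.5%. Compound 2 `N#Cc1ccc(-n2nc(-c3ccc(C(F)(F)F)cc3O)nc2-c2ccccc2O)cc1` gives 66.6%, and compound 3 `Oc1cc(C(F)(F)F)ccc1-c1nc(-c2ccccc2O)n(-c2cccc(F)c2)n1` gives 67.2%. Compound 3 thus carries the highest of the three numbers, but the difference a number 1.7 percentage points higher from compound 1 to compound 3 (within the scatter) and the difference a number 0.6 percentage points higher from compound 2 to compound 3 (within the scatter) both lie within the scatter, so the three compounds cannot be told apart on these data.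

The next compound, compound 4 `Cc1cc(C)cc(-n2nc(-c3ccc(C(F)(F)F)cc3O)nc2-c2ccccc2O)c1`, is not yet measured. Its change from compound 3 is 3,5-dimethylphenyl in place of 3-fluorophenyl on an aromatic nitrogen. Two of the measured steps bear directly on this place: the step of a number 1.7 percentage points higher from compound 1 to compound 3 (within the scatter) and the step of a number 0.6 percentage points higher from compound 2 to compound 3 (within the scatter) each exchanged the group on the same aromatic nitrogen, and neither moved the read-out beyond the scatter. The third step, a number 1.1 percentage points higher from compound 1 to compound 2 (within the scatter), touched a substituent on the aryl at that nitrogen and was likewise within the scatter.

On that basis compound 4 is expected to show no step beyond the scatter, estimated as a number 0.2 percentage points lower from compound 3 to compound 4 (within the scatter). The estimate for compound 4 in this assay is 67%, with a range from 57% to 77%.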

Compound 4, a percentage reported as activity, at one concentration (the size of the read-out at that concentration, not a potency): 76.9%
Beside the measured number, compound 4's estimate is 9.9 percentage points below it, and the stated range covers the measured number.
By their numbers in this assay, from the lowest: compounds 1, 2, 3 and 4 (each within the scatter of the next, the first and the last beyond it).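

In this assay, among these compounds, 3,5-dimethylphenyl on the aromatic nitrogen gives the first steps at this position that pass the scatter: replacing 4-(trifluoromethoxy)phenyl gives a number 11.4 percentage points higher from compound 1 to compound 4 (beyond the scatter) and replacing 4-cyanophenyl gives a number 10.3 percentage points higher from compound 2 to compound 4 (beyond the scatter) while the exchanges among the three earlier aryl groups all stayed within it. Replacing 3-fluorophenyl with the same group gives a number 9.7 percentage points higher from compound 3 to compound 4 (within the scatter) so compound 3 and compound 4 cannot be told apart, and the separation holds only against two of the three earlier groups. No measurement at hand accounts for these differences.

The compounds shown leave open whether both methyl groups are needed for this separation, a question that 3-methylphenyl on the same nitrogen would address, and whether an aryl carrying an amine or a carboxylic acid, or a longer alkyl chain in place of the aryl, would fall in the same range. On these data alone, the trifluoromethyl and hydroxy groups on the other aryl rings stay the same throughout, so it also remains open whether these steps at the nitrogen would persist if those groups were changed.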